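Phenethyl to Methylthiophene: Cytotoxicity Expected Unchanged

A few compounds are considered here, and "the series" means these few. Any claim that something is new, unique, unknown or untested is made for them only; others in the source may bear on it.

Compound 2 `O=C(CCc1ccccc1)c1ccn(-c2ccc3c(c2)B(O)OC3)c1` carries a phenethyl group on its carbonyl carbon. In an ADME assay on L929 cells (Mus musculus) for cytotoxicity, read by resazurin assay, with a stated time of 72 h (on this read-out higher numbers stand for weaker inhibition and lower numbers for stronger inhibition), compound 2 gives > 10 ug/mL, which is a limit of the assay rather than a number. Compound 1 `COc1ccc(C(=O)c2ccn(-c3ccc4c(c3)B(O)OC4)c2)cc1` likewise gives > 10 ug/mL in this assay, again only a limit. Going by the values given here, the step that the two limits leave unreadable from compound 1 to compound 2 is thus not readable, and the limit of > 10 ug/mL in this assay, at which 2 of the 2 values shown sit, is the only evidence at hand. Compound 3 `Cc1ccc(C(=O)c2ccn(-c3ccc4c(c3)B(O)OC4)c2)s1` differs from compound 2 in one place: 5-methylthiophen-2-yl in place of phenethyl on a carbonyl carbon. Among the compounds with values here, no measured step bears on this change. Compound 3 is expected to give an estimated 20 ug/mL, ranging from 5 ug/mL to 80 ug/mL. The expected step is a step that the limit leaves unreadable from compound 2 to compound 3.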

Compound 3, half-maximal inhibitory concentration: > 10 ug/mL
Compound 3 was reported as a limit; the forecaster's own chance of this, stated with the estimate: 80%; the middle value lies beyond the limit too.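

No step can be read among compound 1, compound 2 and compound 3, as each result in this assay is only a limit: the limit of > 10 ug/mL in this assay, at which 3 of the 3 values shown sit.

On these data alone, whether changing the group on the carbonyl carbon alters cytotoxicity at all remains open.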